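The source may hold more compounds than are shown below. What is called first, only, known or untested is meant among the compounds shown, and "the series" means these compounds.

Working notes on the series in a functional assay on Bel-7402 cells (Homo sapiens) for inhibition, read by MTT assay, with a stated time of 24 h, tested at 1 ug/mL; on this read-out lower numbers stand for less inhibition of growth and higher numbers for more inhibition of growth at the one concentration tested. Compound 1 `CC(=O)SCCC(CCCCC(=O)Nc1ccccc1Cl)SC(C)=O` gives 5.01%; compound 2 `CC(=O)SCCC(CCCCC(=O)Nc1cccc(Cl)c1)SC(C)=O` gives 0.56%. The change between them is 3-chlorophenyl in place of 2-chlorophenyl on an amide-type nitrogen and its step is a number 4.5 percentage points lower from compound 1 to compound 2 (within the scatter). Compound 3 `O=C(CCCCC(CCSC(=O)c1ccccc1)SC(=O)c1ccccc1)Nc1ccccc1Cl` gives 7.37%; the difference between the core of compound 1 and the core of compound 3 is not broken down here, so the two values are only set side by side. Compound 4 `O=C(CCCCC(CCSC(=O)c1ccccc1)SC(=O)c1ccccc1)Nc1cccc(Cl)c1` has not yet been measured in this assay. It differs from compound 3 by 3-chlorophenyl in place of 2-chlorophenyl on an amide-type nitrogen, the same change seen from compound 1 to compound 2, at the same place. The expected step is a number 3.4 percentage points lower from compound 3 to compound 4 (within the scatter), small because the earlier step of a number 4.5 percentage points lower from compound 1 to compound 2 (within the scatter) was within the scatter. Compound 4 is therefore expected near 4%, between -6% and 14%.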

Compound 4, percent growth inhibition at one concentration: "not active" (no number reported)
Nothing numeric was reported for compound 4; there is nothing to compare the estimate with.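

Among the compounds shown here, compound 4 is reported in this assay only as not active, with no number, so no step from compound 3 to compound 4 can be read. No evidence bears on this result. The compounds shown leave open how large the change from 2-chlorophenyl to 3-chlorophenyl is on the core of compound 3.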